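The compounds below may be only part of what the source reports. "The series", "measured", "known", "first", "only" and "open" are said of these compounds alone.

Measured compounds in the series:

compound 1, `COc1cc(C(=O)N/N=C/c2cccc(F)c2)cc(OC)c1OC`: 53.5%
compound 2, `COc1cc(C2=NN(C(C)=O)C(c3ccc(Cl)c(Cl)c3)O2)cc(OC)c1OC`: 28.1%
compound 3, `COc1cc(C(=O)N/N=C/c2ccc(Cl)c([N+](=O)[O-])c2)cc(OC)c1OC`: 32.1%

All three were run in a functional assay on PC-3 cells (Homo sapiens) for antiproliferative activity, read by MTT assay, tested at 1 uM; a higher number here means a stronger effect of the compound at the concentration tested, a lower number a weaker effect. Compound 2 gives 28.1%, the lowest of the three numbers; compound 3 stands nearest to it, within the usual scatter, so the two cannot be told apart on these figures. Compound 1 stands furthest from compound 2, higher and beyond the scatter, so compound 1 does show a stronger effect than compound 2 at this concentration.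

Compound 4 is `COc1cc(C2=NN(C(C)=O)C(c3cccc(C(F)(F)F)c3)O2)cc(OC)c1OC`. It differs from compound 2 in one place: 3-(trifluoromethyl)phenyl in place of 3,4-dichlorophenyl on a saturated ring carbon. Both groups are single carbon aromatic rings without donors or acceptors, and the rest of the molecule, including the acetyl group on the five-membered ring, is kept. Going by the values given here, no measured pair shows such a change on its own, so there is nothing to read the size of the step from. The expectation is therefore a step in this assay from compound 2 to compound 4 of a number 1.9 percentage points higher from compound 2 to compound 4 (within the scatter), not beyond the scatter in either direction. Compound 4 is estimated at 30%, with a range from 15% to 46%.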

Compound 4, a percentage reported as inhibition, at one concentration (the size of the read-out at that concentration, not a potency): 30.1%
Compound 4: middle estimate off by 0.1 percentage points, on the low side; low and high end bracket the measured number.
By their numbers in this assay, from the lowest: compounds 2, 4 and 3 (each within the scatter of the next); then compound 1.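

Going by these compounds alone, on the saturated ring carbon of the five-membered ring, 3-(trifluoromethyl)phenyl in place of 3,4-dichlorophenyl gives in this assay a number 2 percentage points higher from compound 2 to compound 4 (within the scatter) and is the only step so far that can be read. The two substituted phenyl rings cannot be told apart at the concentration tested, so this position carries either one, with the acetyl group kept, without a difference beyond the scatter. Nothing at hand bears on why the read-out stays level across this change.

Open, going by these compounds, is whether a phenyl ring carrying an amine or a carboxylic acid, or a butyl chain in place of the ring, would hold the read-out at this level on the same carbon. Also open, on these data alone, is whether a propanoyl group in place of the acetyl group would shift it.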